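The source may report more compounds than this note shows. Statements on the series, on what has been measured and on what is new or still open speak of the compounds shown alone.

Compound 1 `CCCCCCCCCCCCCC(=O)Nc1nnc(S[C@@H]2O[C@H](COC(C)=O)[C@H](OC(C)=O)[C@H](OC(C)=O)[C@H]2OC(C)=O)s1`: "not active" (no number reported)
Compound 2 `CCCCCCCC/C=C\CCCCCCCC(=O)Nc1nnc(S[C@@H]2O[C@H](COC(C)=O)[C@H](OC(C)=O)[C@H](OC(C)=O)[C@H]2OC(C)=O)s1`: "not active" (no number reported)
Compound 3 `CCCCCCCC(=O)Nc1nnc(S[C@@H]2O[C@H](CO)[C@H](O)[C@H](O)[C@H]2O)s1`: 56000 nM

All three compounds were tested in a functional assay on SK-OV-3 cells (Homo sapiens) for cytotoxicity, read by MTT assay, with a stated time of 24 h; on this read-out higher numbers stand for weaker inhibition and lower numbers for stronger inhibition. Going by the values given here, compound 3, at 56000 nM, holds the only number in this small set. Compound 1 and compound 2 gave no number, so compound 3 cannot be placed on a numerical scale against them. Its value alone shows only that a high concentration was needed to reach the half-way point.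

The next compound to be tested is compound 4 `CCCCCC(=O)Nc1nnc(S[C@@H]2O[C@H](CO)[C@H](O)[C@H](O)[C@H]2O)s1`. The change from compound 3 is confined to the chain: hydrogen in place of ethyl on a saturated chain carbon, five bonds along the chain from a carbonyl carbon. In words, hydrogen stands in place of ethyl on a saturated chain carbon, five bonds along the chain from a carbonyl carbon. Everything else stays the same.

Among the compounds with values here, no measured pair in this set shows what such a shortening does, so any forecast is uncertain. The expectation is a small move towards weaker inhibition, perhaps hardly beyond the usual scatter, and no large gain. With compound 3 at 56000 nM as the sole anchor, the range has to stay wide. The expected change is a 1.4-fold higher number from compound 3 to compound 4 (0.15 log units; within the scatter). The estimated value for compound 4 is 80000 nM, within an expected range of 30000 nM to 200000 nM.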

Compound 4, half-maximal inhibitory concentration: "not active" (no number reported)
The entry for compound 4 holds no number; no gap can be computed for the estimate.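

Going by these compounds alone, compound 3 gives 56000 nM while compound 4 gives "not active" (no number reported) with no number, so no step of any size can be read between compound 3 and compound 4. No supporting evidence bears on this result. The compounds shown leave open how far hydrogen in place of ethyl on this chain changes the strength of inhibition.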